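The source may report more compounds than this note shows. Statements on the series, on what has been measured and on what is new or still open speak of the compounds shown alone.

Measured compounds:
compound 1, `O=C1O/C(=C\Cn2cc(-c3ccc(Br)cc3)nn2)C(OCc2ccccc2)=C1OCc1ccccc1` — > 100000 nM, a limit of the assay
compound 2, `Cc1ccc(-c2cn(C/C=C3\OC(=O)C(OCc4ccccc4)=C3OCc3ccccc3)nn2)cc1` — > 100000 nM, a limit of the assay
compound 3, `CC(C)(C)c1cn(C[C@H](O)[C@H]2OC(=O)C(OCc3ccccc3)=C2OCc2ccccc2)nn1` — 35800 nM

In a functional assay on SW-620 cells (Homo sapiens) for antiproliferative activity, read by MTT assay, with a stated time of 72 h (a lower number here means a stronger inhibitor, a higher number a weaker inhibitor), compound 1 gives > 100000 nM, which is a limit of the assay and not a number. Compound 2 gives > 100000 nM, again a limit. Within the data shown here, compound 3 gives 35800 nM, the only number among the three values shown. Among the measured compounds shown here, the one measured step, a step that the two limits leave unreadable from compound 1 to compound 2, methyl in place of bromo on an aromatic carbon, cannot be read because both of its compounds sit at the limit of > 100000 nM in this assay, at which 2 of the 3 values shown sit.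

Compound 4, `O=C1O[C@H]([C@@H](O)Cn2ccnn2)C(OCc2ccccc2)=C1OCc1ccccc1`, differs from compound 3 by hydrogen in place of tert-butyl on an aromatic carbon. No measured step bears on this change: the only step shown is unreadable, and it concerns a different group on a different ring. There is therefore no measured ground to expect a step beyond the scatter in this assay in either direction, and the expectation for compound 4 must be wide. Compound 4 is estimated at 55000 nM, within a range of 15000 nM to 200000 nM, which means an expected step of a 1.5-fold higher number from compound 3 to compound 4 (0.19 log units; within the scatter) from compound 3 to compound 4.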

Compound 4, half-maximal inhibitory concentration: > 100000 nM
Compound 4: only a limit was reported (the forecaster's own chance of this, stated with the estimate: 40%); at least 1.8-fold (0.25 log units) between middle value and limit.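

In this assay, among these compounds, the change from 4-(tert-butyl)-1H-1,2,3-triazol-1-yl to 1H-1,2,3-triazol-1-yl gives the first step that can be read, an at least 2.7-fold higher number from compound 3 to compound 4 (0.44 log units; beyond the scatter). Compound 4 gives > 100000 nM, a limit of the assay and not a number. The tert-butyl on this aromatic carbon thus matters to the measured value, something the earlier compounds could not show, and compound 3 remains the only compound with a number: the limit of > 100000 nM in this assay, at which 3 of the 4 values shown sit.

The compounds shown leave open how large the step really is, since only its lower bound can be read. They also leave open whether an ethyl chain, an amine or a carboxylic acid on this same aromatic carbon would keep the value of compound 3 or move it further in either direction.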